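A few compounds are considered here, and "the series" means these few. Any claim that something is new, unique, unknown or untested is made for them only; others in the source may bear on it.

Measured so far in an ADME assay on Vero cells (Chlorocebus sabaeus) for cytotoxicity, read by fluorescence and resazurin assay, with a stated time of 3 days; a higher number here means that more compound is tolerated, a lower number that less compound is tolerated:
compound 1 `CC1(C)O[C@H]2O[C@H](Cn3cc(CN4C(=O)/C(=N\Nc5ccccc5)c5ccccc54)nn3)[C@H](O)[C@H]2O1` — 82100 nM
compound 2 `COc1ccc(N/N=C2\C(=O)N(Cc3cn(C[C@H]4O[C@@H]5OC(C)(C)O[C@@H]5[C@H]4O)nn3)c3ccccc32)cc1` — 74500 nM
compound 3 `O=C1/C(=N\Nc2ccccc2)c2ccccc2N1Cc1cn(O[C@@H]2O[C@H](CO)[C@@H](O)[C@H](O)[C@H]2O)nn1` — 88500 nM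

Compound 3 stands within the scatter of both other compounds: its gap to compound 1 and its gap to compound 2 are each within the scatter, so the three numbers do not separate.

Compound 4 `COc1ccc(N/N=C2\C(=O)N(Cc3cn(O[C@@H]4O[C@H](CO)[C@@H](O)[C@H](O)[C@H]4O)nn3)c3ccccc32)cc1` differs from compound 3 by methoxy in place of hydrogen on an aromatic carbon. Among the measured compounds shown here, the one measured step of the same kind is a 1.1-fold lower number from compound 1 to compound 2 (0.04 log units; within the scatter), made on compound 1; it stayed within the scatter. On that basis the step to compound 4 is expected to be a 1.1-fold lower number from compound 3 to compound 4 (0.04 log units; within the scatter), with no movement beyond the scatter in either direction. Compound 4 is therefore estimated at 80000 nM in this assay, with a range of 50000 nM to 130000 nM.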

Compound 4, half-maximal cytotoxic concentration: 79600 nM
For compound 4 the middle estimate is 1.0-fold (0.00 log units) above the measured one; measured number inside the range.
By their numbers in this assay, from the lowest: compounds 2, 4, 1 and 3 (each within the scatter of the next).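

In this assay, methoxy in place of hydrogen on an aromatic carbon now reads on a second core, with a 1.1-fold lower number from compound 3 to compound 4 (0.05 log units; within the scatter), so this para position has stayed within the scatter on both cores: the same change on two cores in this assay, a 1.1-fold lower number (0.04 log units; within the scatter) from compound 1 to compound 2 and a 1.1-fold lower number (0.05 log units; within the scatter) from compound 3 to compound 4, 1.0-fold (0.00 log units) apart, within the scatter of two such steps. The exchange of the group on the aromatic nitrogen also reads on a second pair, with a 1.1-fold higher number from compound 2 to compound 4 (0.03 log units; within the scatter), and it too stays within the scatter: the same change on two cores in this assay, a 1.1-fold higher number (0.03 log units; within the scatter) from compound 1 to compound 3 and a 1.1-fold higher number (0.03 log units; within the scatter) from compound 2 to compound 4, 1.0-fold (0.00 log units) apart, within the scatter of two such steps.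

As far as these compounds go, whether an amine or a carboxylic acid at this para position would give a step beyond the scatter stays open. The same holds for a longer chain on the aromatic nitrogen.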